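The source may report more compounds than this note shows. Statements on the series, on what has been measured and on what is new or still open speak of the compounds shown alone.

Compound 1 `CC(=O)c1ccc(OCCCCC#N)cc1O` gives 0% in an assay on isolated protein for inhibition of leukotriene B4 receptor 1 (Homo sapiens), tested at 10 uM; a higher number here means more inhibition at the concentration tested (going by the name of the read-out), a lower number less inhibition.
Compound 2 `C=CCc1cc(C(C)=O)c(O)cc1OCC#N` gives 20% in this assay.

Compound 2 stands highest of the two numbers; its nearest neighbour is compound 1, whose value lies lower by a gap beyond the scatter. Compound 3 `C=CCc1cc(C(C)=O)c(O)cc1OCCCCC#N` differs from compound 2 by 3-cyanopropyl in place of cyano on a saturated chain carbon bound to an oxygen on an aromatic ring. Going by the values given here, no measured step covers this change. Compound 1 carries the longer chain without the allyl group and gives 0% in this assay, so a drop, or no step beyond the scatter, is expected here. The estimate for compound 3 is 12%, within 0% to 35%. The expected step is a number 8 percentage points lower from compound 2 to compound 3 (within the scatter).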

Compound 3, a percentage reported as inhibition, at one concentration (the size of the read-out at that concentration, not a potency): 92%
Beside the measured number, compound 3's estimate is 80 percentage points below it; the whole stated range lies below it.
By their numbers in this assay, from the lowest: compound 1; then compound 2; then compound 3.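

Going from cyano to 3-cyanopropyl on a saturated chain carbon bound to an oxygen on an aromatic ring gives a number 72 percentage points higher from compound 2 to compound 3 (beyond the scatter) in this assay, so this position responds strongly to the change. With that chain held constant, allyl in place of hydrogen on an aromatic carbon gives a number 92 percentage points higher from compound 1 to compound 3 (beyond the scatter) as well. Among these compounds, the 3-cyanopropyl group gives high inhibition only with allyl present. Going by these compounds, whether a longer chain or a carboxylic acid in place of the nitrile would hold this level remains open. No available evidence bears on the origin of these large steps.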